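The source may report more compounds than this note shows. Statements on the series, on what has been measured and on what is new or still open speak of the compounds shown alone.

Compound 2 `COc1cc(/C=C/c2cc(/C=C/c3cc(OC)c(OC)c(OC)c3)nc(OCCCCBr)n2)cc(OC)c1OC` was tested in a functional assay on HT-29 cells (Homo sapiens) for cytotoxicity, read by fluorescence and resazurin assay, with a stated time of 48 h; a lower number here means a stronger inhibitor, a higher number a weaker inhibitor. In this assay compound 2 gives > 20000 nM, which is a limit of the assay rather than a number. Two related compounds were tested in the same way. In this assay compound 1 `COc1ccc(/C=C/c2cc(/C=C/c3ccc(OC)cc3)nc(OCCCCCBr)n2)cc1` gives > 20000 nM, again a limit. In this assay compound 3 `BrCCCCOc1nc(/C=C/c2ccccc2)cc(/C=C/c2ccccc2)n1` gives > 20000 nM, also a limit. All three values thus sit at the same limit (the limit of > 20000 nM in this assay, at which 3 of the 3 values shown sit), and compound 2 cannot be placed higher or lower than the others on these numbers.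

Compound 4 `COc1cc(/C=C/c2cc(/C=C/c3cc(OC)c(OC)c(OC)c3)nc(OCCCCCBr)n2)cc(OC)c1OC` differs from compound 2 in one place: bromomethyl in place of bromo on a saturated chain carbon, four bonds along the chain from an oxygen on an aromatic ring. Within the data shown here, no measured pair shows what such a change does here, and three values at the limit give no foothold for a direction. The step expected in this assay is a step that the limit leaves unreadable from compound 2 to compound 4, which is no step beyond the usual scatter. Compound 4 is therefore expected to give 30000 nM, within 12000 nM to 100000 nM, most likely reported once more only as a limit.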

Compound 4, half-maximal inhibitory concentration: > 20000 nM
Compound 4 ended at the assay's limit; the forecaster's own chance of this, stated with the estimate: 85%; the middle value is on the limit's open side.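

No step can be read between compound 2 and compound 4, as each gives only a limit in this assay and not a number: the limit of > 20000 nM in this assay, at which 4 of the 4 values shown sit.

The compounds shown leave open whether bromomethyl in place of bromo changes cytotoxicity at all, and how strong any of these four compounds really is.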